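A few compounds are considered here, and "the series" means these few. Any claim that something is new, unique, unknown or untested is made for them only; others in the source may bear on it.

Measured so far in a functional assay on MCF7 cells (Homo sapiens) for cytotoxicity, read by MTT assay, with a stated time of 72 h; a higher number here means a weaker inhibitor, a lower number a stronger inhibitor:
- Compound 1 `COc1ccc2[nH]c(-c3ccc[nH]3)c(C3CC(=O)NC3=O)c2c1`: 19000 nM
- Compound 2 `O=C1CC(c2c(-c3ccc[nH]3)[nH]c3ccccc23)C(=O)N1`: 35000 nM

Among the compounds with values here, these are the only two numbers available. Compound 2 and compound 1 lie within the scatter of each other, so neither can be ranked ahead.

The next compound, compound 3 `Cc1ccc2[nH]c(-c3ccc[nH]3)c(C3CC(=O)NC3=O)c2c1`, differs from compound 2 at one place: methyl in place of hydrogen on an aromatic carbon. In plain words, this is methyl in place of hydrogen on an aromatic carbon.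

Within the data shown here, the only measured step that bears on this is a 1.8-fold higher number from compound 1 to compound 2 (0.27 log units; within the scatter), where hydrogen takes the place of methoxy on an aromatic carbon. Methyl is a different group, so this guide is a loose one, but no change beyond the scatter is expected in this assay. The expected step is a 1.4-fold lower number from compound 2 to compound 3 (0.15 log units; within the scatter). For compound 3 the estimated value is 25000 nM, with an expected range of 12000 nM to 50000 nM.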

Compound 3, half-maximal inhibitory concentration: 29000 nM
Beside the measured number, compound 3's estimate is 1.2-fold (0.06 log units) below it, within the range that was stated.
By their numbers in this assay, from the lowest: compounds 1, 3 and 2 (each within the scatter of the next).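

In this assay, putting a methyl group on this aromatic carbon gives a 1.2-fold lower number from compound 2 to compound 3 (0.08 log units; within the scatter), and swapping methoxy for methyl gives a 1.5-fold higher number from compound 1 to compound 3 (0.18 log units; within the scatter). With a third group now at the same place, all three pairs among hydrogen, methyl and methoxy lie within the scatter, so these groups cannot be ranked against one another at this position. No measurement shown here gives a reason for these numbers.

On these data alone, whether an amine, a carboxylic acid or a chlorine atom on this carbon would produce a step beyond the scatter remains open. The compounds shown also leave open what a change elsewhere on the shared core would do, since all three differ only at this one place.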